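A few compounds are considered here, and "the series" means these few. Any claim that something is new, unique, unknown or untested is made for them only; others in the source may bear on it.

Three compounds were measured in a functional assay on the whole organism (strain Wistar albino) for inhibition, with Rattus norvegicus as the target, read by paw edema, with stated times of 30 min and 0.5 h, at a dose of 20 mg/kg by the oral route; a lower number here means less inhibition, a higher number more inhibition at the dose given (going by the name of the read-out):

compound 1 `Cc1nn2c(C(C)c3ccc(CC(C)C)cc3)nnc2s1`: 64%
compound 2 `CCc1nn2c(C(C)c3ccc(CC(C)C)cc3)nnc2s1`: 5%
compound 3 `CCCc1nn2c(C(C)c3ccc(CC(C)C)cc3)nnc2s1`: 10%

Compound 3 stands second highest of the three numbers. The step of a number 5 percentage points higher from compound 2 to compound 3 (within the scatter) separates it from its nearest neighbour, and the step of a number 54 percentage points lower from compound 1 to compound 3 (beyond the scatter) from its furthest.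

Compound 4 `CC(C)Cc1ccc(C(C)c2nnc3sc(-c4ccc(Br)cc4)nn23)cc1` differs from compound 3 by 4-bromophenyl in place of propyl on an aromatic carbon. The measured steps at this place concern the chain alone: a number 59 percentage points lower from compound 1 to compound 2 (beyond the scatter) and a number 54 percentage points lower from compound 1 to compound 3 (beyond the scatter) were large falls once the chain grew past methyl, whereas a number 5 percentage points higher from compound 2 to compound 3 (within the scatter) stayed within the scatter. Among the compounds with values here, no measured step puts a ring at this place, so the three numbers give no direct guide to a 4-bromophenyl there. With the two longer chains sitting low and close to each other, a modest change in either direction is the cautious expectation. For compound 4 the estimated step is a number 8 percentage points higher from compound 3 to compound 4 (within the scatter). Compound 4 is estimated at 18%, with a range from 0% to 45%.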

Compound 4, a percentage reported as inhibition, in the whole organism at one dose (the size of the read-out at that dose, not a potency): 28%
Compound 4: middle estimate off by 10 percentage points, on the low side; the range from low to high includes it.
By their numbers in this assay, from the lowest: compounds 2 and 3 (each within the scatter of the next); then compound 4; then compound 1.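

In this assay compound 4 places a ring on this aromatic carbon, and the change lifts the number over both longer chains, with a number 18 percentage points higher from compound 3 to compound 4 (beyond the scatter) and a number 23 percentage points higher from compound 2 to compound 4 (beyond the scatter). The number at this place therefore does not simply fall as the group grows, since 4-bromophenyl, with 7 heavy atoms against the 3 of propyl, sits above propyl, though methyl still goes against any such gain, with a number 36 percentage points lower from compound 1 to compound 4 (beyond the scatter). Nothing available gives a reason for this order.

Within the data shown here, whether the rise belongs to the ring itself or to the bromine on it stays open, with only this one ring at the position. Also open, on these data alone, is how an unsubstituted phenyl, a 4-methoxyphenyl or a small amine on this carbon would compare with methyl.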